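The compounds below may be only part of what the source reports. "The series", "measured", "known", "first", "only" and "open" are said of these compounds alone.

Measured in an ADME assay on MT4 cells (Homo sapiens) for cytotoxicity; a higher number here means that more compound is tolerated, a lower number that less compound is tolerated:

compound 1, `Cc1cc(C)cc(Cn2c(SCC(=O)Nc3ccccc3Cl)nc3ccc(Cl)cc32)c1`: 141000 nM
compound 2, `Cc1cc(C)cc(S(=O)(=O)n2c(SCC(=O)Nc3ccccc3Cl)nc3ccc(Cl)cc32)c1`: 99300 nM
compound 3, `Cc1cc(C)cc(Cn2c(SCC(=O)Nc3ccc(S(N)(=O)=O)cc3Cl)nc3ccccc32)c1`: 111000 nM

Compounds 1 and 2 share a core and differ in one place: (3,5-dimethylphenyl)sulfonyl in place of 3,5-dimethylbenzyl on an aromatic nitrogen. In this assay this gave a 1.4-fold lower number from compound 1 to compound 2 (0.15 log units; within the scatter), so the two numbers are not distinguishable. Compound 3 carries a core that is not the same as that of compound 1; the difference between the two cores is not broken down here. Its value in this assay sits close to those of compound 1 and compound 2, and none of the three is set apart from the others.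

Compound 4, `Cc1cc(C)cc(S(=O)(=O)n2c(SCC(=O)Nc3ccc(S(N)(=O)=O)cc3Cl)nc3ccccc32)c1`, has not yet been measured. It stands to compound 3 as compound 2 stands to compound 1: (3,5-dimethylphenyl)sulfonyl in place of 3,5-dimethylbenzyl on an aromatic nitrogen. The place of the change is described in the same words for both pairs, so it is the same change, carried over onto the core of compound 3.

For the measured compounds named here, because the only measured instance of this change gave a 1.4-fold lower number from compound 1 to compound 2 (0.15 log units; within the scatter), compound 4 is expected to come out close to compound 3, with at most a small shift toward a lower number. On that basis compound 4 is estimated at 82000 nM in this assay, with a range from 40000 nM to 170000 nM. The step this estimate means is a 1.4-fold lower number from compound 3 to compound 4 (0.13 log units; within the scatter), which is expected to lie within the usual scatter. A single prior instance is a thin base, so the range is kept wide.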

Compound 4, half-maximal cytotoxic concentration: 25600 nM
Compound 4: the middle estimate sits 3.2-fold (0.51 log units) above what was measured; measured number below the stated range.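

In this assay, placing (3,5-dimethylphenyl)sulfonyl instead of 3,5-dimethylbenzyl on the aromatic nitrogen of the core of compound 3 gave a 4.3-fold lower number from compound 3 to compound 4 (0.64 log units; beyond the scatter), a step that can be told apart from the scatter of the measurements. This change therefore did not carry over from one core to the other at a constant size, and the step read on the first pair was a poor guide to the step on the second: the same change on two cores in this assay, a 1.4-fold lower number (0.15 log units; within the scatter) from compound 1 to compound 2 and a 4.3-fold lower number (0.64 log units; beyond the scatter) from compound 3 to compound 4, 3.1-fold (0.48 log units) apart, beyond the scatter of two such steps What this does not show is which feature of the core of compound 3 goes with the larger step, since the difference between the two cores is not broken down, and two pairs cannot say how a third core would respond.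

The compounds shown leave open whether a different link on the same aromatic nitrogen, such as a carbonyl in place of the sulfonyl or a longer chain in place of the single carbon of the benzyl group, would give a step of either size. They also leave open how the change would behave on a core carrying a carboxylic acid or an amine.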